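The source may hold more compounds than are shown below. What is called first, only, known or untested is meant among the compounds shown, and "the series" means these compounds.

Working notes, series read in an assay on HEK293 cells for positive allosteric modulation of metabotropic glutamate receptor 5 (Homo sapiens), read by FLIPR; on this read-out lower numbers stand for an effect already at smaller amounts and higher numbers for an effect only at larger amounts of compound.

Measured so far:
compound 1 `O=C(c1ccc(Cl)cc1)N1CC(c2nc(-c3cccc(F)c3)no2)C1` gives 2500 nM
compound 2 `O=C(C1CCCCC1)N1CC(c2nc(-c3cccc(F)c3)no2)C1` gives 1000 nM
compound 3 `CC1CCCC(C(=O)N2CC(c3nc(-c4cccc(Cl)c4)no3)C2)C1` gives 410 nM

Compound 3 has the lowest number of the three in this assay; compound 2 stands nearest to it and compound 1 furthest, and both of those separations are beyond the scatter. Compound 4 `O=C(N1CCCCCC1)N1CC(c2nc(-c3cccc(Cl)c3)no2)C1` has not been measured. It differs from compound 3 in one place: azepan-1-yl in place of 3-methylcyclohexyl on a carbonyl carbon. The ring keeps its heavy-atom count, but a carbon-only six-membered ring with a methyl branch is exchanged for a seven-membered ring holding one nitrogen, joined to the carbonyl carbon.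

Within the data shown here, only one step touches the substituent on that carbonyl carbon: a 2.5-fold lower number from compound 1 to compound 2 (0.40 log units; beyond the scatter). It shows that exchanging this substituent can shift the number by a modest amount. Among the measured compounds shown here, no measured pair compares a nitrogen-containing ring with a carbon ring at this position, nor a seven-membered ring with a six-membered one, so the direction of the present change is not fixed by the data. A step of modest size in either direction, or none beyond the scatter, is the reasonable expectation, with the centre placed slightly toward a higher number given that compound 3 already sits at the low end of the set. Compound 4 is therefore estimated at 800 nM, within 250 nM to 2500 nM, which corresponds to an expected 2.0-fold higher number from compound 3 to compound 4 (0.29 log units; within the scatter).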

Compound 4, half-maximal effective concentration: 47 nM
The estimate for compound 4 lay 17-fold (1.23 log units) above the measured number; the measured number lies below the stated range.
By their numbers in this assay, from the lowest: compound 4; then compound 3; then compound 2; then compound 1.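

In this assay, among these compounds, the substituent on the carbonyl carbon can move the number much further than the earlier compounds indicated: the new step, an 8.7-fold lower number from compound 3 to compound 4 (0.94 log units; beyond the scatter), compares with a 2.5-fold lower number from compound 1 to compound 2 (0.40 log units; beyond the scatter), the only earlier step at this place, although the two steps rest on different remaining structures. The change from 3-methylcyclohexyl to azepan-1-yl keeps the heavy-atom count and the count of hydrogen-bond donors and acceptors, so the lower number comes with a change in ring size, the exchange of one ring carbon for nitrogen and the loss of the methyl branch, which this single step cannot separate. Nothing at hand gives a reason for the size or direction of this step.

Still open, from the compounds shown here alone, is which of these differences carries the change: piperidin-1-yl, a six-membered ring holding nitrogen, and cycloheptyl, a seven-membered ring of carbon only, would divide ring size from the nitrogen at this carbonyl carbon. Also open, going by these compounds, are whether azepan-1-yl gives a similar step on the core of compound 2, and whether an open-chain diethylamino group can stand in for the ring.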